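A few compounds are considered here, and "the series" means these few. Any claim that something is new, unique, unknown or untested is made for them only; others in the source may bear on it.

Compound 1 `O=c1oc2ccccc2c(Cl)c1/C=N/c1ccc(S(=O)(=O)Nc2nccs2)cc1` gives 300 nM in a functional assay on B16-F10 cells (Mus musculus) for cytotoxicity, read by CCK-8 assay, with a stated time of 48 h; on this read-out lower numbers stand for stronger inhibition and higher numbers for weaker inhibition.
Compound 2 `N=C(N)NS(=O)(=O)c1ccc(/N=C/c2c(Cl)c3ccccc3oc2=O)cc1` gives 180 nM in this assay.
Compound 3 `Cc1ccnc(NS(=O)(=O)c2ccc(/N=C/c3c(Cl)c4ccccc4oc3=O)cc2)n1` gives 230 nM in this assay.

Compound 1 has the highest of these three numbers, yet its gap to compound 3 is only a 1.3-fold lower number from compound 1 to compound 3 (0.12 log units; within the scatter) and its gap to compound 2 only a 1.7-fold lower number from compound 1 to compound 2 (0.22 log units; within the scatter), so the three compounds cannot be told apart on these readings. The unmeasured compound 4 `Cc1ccc2oc(=O)c(/C=N/c3ccc(S(=O)(=O)Nc4nccs4)cc3)c(Cl)c2c1` differs from compound 1 in one place: methyl in place of hydrogen on an aromatic carbon. Among the compounds with values here, this is a change on the fused ring of the shared core, a place that none of the measured steps touches. The steps measured so far, including a 1.3-fold higher number from compound 2 to compound 3 (0.11 log units; within the scatter), all exchange the group on the sulfonamide nitrogen, and every one of them stayed within the scatter. Within the data shown here, they therefore say nothing direct about a methyl on the fused ring; the only guidance is that the core has so far carried varied changes without a clear shift in this assay. A small methyl added to an aromatic carbon is expected to behave in the same way, so the expected step is no change at the digits printed from compound 1 to compound 4 (within the scatter), which is none beyond the scatter. Compound 4 is accordingly estimated at 300 nM, with a range from 120 nM to 750 nM.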

Compound 4, half-maximal inhibitory concentration: 280 nM
Estimate against measurement, compound 4: 1.1-fold (0.03 log units) above; measured number inside the range.
By their numbers in this assay, from the lowest: compounds 2, 3, 4 and 1 (each within the scatter of the next).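

Within the data shown here, the earlier compounds differ only in the group on the sulfonamide nitrogen, so compound 4 gives the first reading for a change on the fused ring of the shared core: in this assay, methyl in place of hydrogen on this aromatic carbon gives a 1.1-fold lower number from compound 1 to compound 4 (0.03 log units; within the scatter) and no shift can be read. This position, meta to a fused ring and para to a fused ring, can therefore carry a methyl without a measurable difference in this cell read-out, although one small group is a narrow test of the position. No measurement is available that would explain this result, so it stands as an observation only.

The compounds shown leave open whether an amine, a carboxylic acid or a longer chain at this position would give a reading as close to that of compound 1 as methyl does. They also leave open whether methyl on this carbon would give the same outcome alongside the groups on the sulfonamide nitrogen of compound 2 and compound 3.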